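The compounds below may be only part of what the source reports. "The series", "measured", "known", "first", "only" and "open" are said of these compounds alone.

Compound 2 `COc1ccc(C(=O)/C=C/c2cc(-c3cc(OC)c(OC)c(OC)c3)n[nH]2)cc1OC` and compound 1 `COc1cc(-c2cc(/C=C/C(=O)c3ccc(Cl)c(Cl)c3)[nH]n2)cc(OC)c1OC` have been measured in a functional assay on SK-OV-3 cells (Homo sapiens) for cytotoxicity, read by sulforhodamine B assay, with a stated time of 48 h, tested at 100 uM; on this read-out higher numbers stand for a weaker effect at the one concentration tested and lower numbers for a stronger effect. In this assay compound 2 gives -98%, the lower of the two numbers; compound 1 gives -70%. There is one recorded step, a number 28 percentage points lower from compound 1 to compound 2 (beyond the scatter). The change in that step sits on the carbonyl carbon. Compound 3 `COc1cc(-c2cc(/C=C/C(=O)c3ccc(F)c(F)c3)[nH]n2)cc(OC)c1OC` differs from compound 2 at that same place: 3,4-difluorophenyl in place of 3,4-dimethoxyphenyl on a carbonyl carbon. A halogenated ring again replaces the dimethoxy ring, so the earlier step is expected to run back partly, giving a number higher than compound 2, a number 20 percentage points higher from compound 2 to compound 3 (beyond the scatter). Compound 3 is expected to give -78%, between -98% and -55%.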

Compound 3, a percentage reported as activity, at one concentration (the size of the read-out at that concentration, not a potency): -5%
Estimate against measurement, compound 3: 73 percentage points below, outside the stated range (above it).
By their numbers in this assay, from the lowest: compound 2; then compound 1; then compound 3.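

On the carbonyl carbon, the two halogenated rings do not read alike in this assay: 3,4-difluorophenyl in place of 3,4-dichlorophenyl gives a number 65 percentage points higher from compound 1 to compound 3 (beyond the scatter) and 3,4-difluorophenyl in place of 3,4-dimethoxyphenyl gives a number 93 percentage points higher from compound 2 to compound 3 (beyond the scatter) at this same place. This position is therefore far more sensitive than the first step showed, and the presence of halogens on the ring does not by itself set the read-out. No measurement here explains the gap.

On these data alone, a 3,4-dibromophenyl ring or a phenyl ring carrying an amine could show whether the sharp loss is specific to fluorine, and that remains open.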